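Notes on the aryl-variant series: compound 3 to compound 4

A few compounds are considered here, and "the series" means these few. Any claim that something is new, unique, unknown or untested is made for them only; others in the source may bear on it.

Three compounds have numbers in an in vitro functional assay on HEK285-7 cells for antagonist activity at prostaglandin D2 receptor 2 (Homo sapiens), read by BRET and beta-arrestin recruitment; a higher number here means a weaker inhibitor, a lower number a stronger inhibitor. Compound 1 `O=C(O)Cc1sc(C(c2ccc(F)cc2)c2ccc(F)cc2)nc1-c1ccccc1` gives 240 nM, compound 2 `O=C(O)Cc1sc(C(c2ccc(F)cc2)c2ccc(F)cc2)nc1-c1cccc(F)c1` gives 18 nM, and compound 3 `COc1cc(-c2nc(C(c3ccc(F)cc3)c3ccc(F)cc3)sc2CC(=O)O)ccn1` gives 380 nM. Compound 3 holds the highest number of the three; one gap is a 1.6-fold higher number from compound 1 to compound 3 (0.20 log units; within the scatter), while the other is a 21-fold higher number from compound 2 to compound 3 (1.32 log units; beyond the scatter). Within the data shown here, the one step that changed the number greatly is a 13-fold lower number from compound 1 to compound 2 (1.12 log units; beyond the scatter).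

Compound 4 `O=C(O)Cc1sc(C(c2ccc(F)cc2)c2ccc(F)cc2)nc1-c1ccnc(O)c1` differs from compound 3 by hydrogen in place of methyl on an oxygen on an aromatic ring. Among the measured compounds shown here, no measured step touches the oxygen substituent; all three steps concern the aryl ring itself, so none bears on this change. The expectation for compound 4 is therefore a step of a 1.1-fold higher number from compound 3 to compound 4 (0.02 log units; within the scatter) in this assay, a change not beyond the scatter. Compound 4 is estimated at 400 nM, in the range 130 nM to 1200 nM.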

Compound 4, half-maximal inhibitory concentration: 890 nM
Compound 4: the middle estimate sits 2.2-fold (0.35 log units) below what was measured, and the stated range covers the measured number.
By their numbers in this assay, from the lowest: compound 2; then compounds 1 and 3 (each within the scatter of the next); then compound 4.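

Among these compounds, the oxygen substituent on the aromatic ring does matter in this assay: hydrogen in place of methyl gives a 2.3-fold higher number from compound 3 to compound 4 (0.37 log units; beyond the scatter), the first measured step at this oxygen. 2-Methoxypyridin-4-yl stayed within the scatter of phenyl, but 2-hydroxypyridin-4-yl does not, with a 3.7-fold higher number from compound 1 to compound 4 (0.57 log units; beyond the scatter), and against 3-fluorophenyl it gives a 49-fold higher number from compound 2 to compound 4 (1.69 log units; beyond the scatter). Nothing available explains the shift at this oxygen.

Still open, as far as these compounds go, is how an ethoxy group or an amine on this carbon would read. Also open, from the compounds shown here alone, is whether fluoro added to the 2-methoxypyridin-4-yl ring would lower the number as it did on phenyl.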